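Changing the group on the ring nitrogen in a rat GIP receptor assay

This account rests on a few compounds, and the source may have more. Where it says the series, first, only, none or still open, it means among the compounds named here.

Compound 1, `Cc1nc(S(C)(=O)=O)ccc1Oc1ncnc(OC2CCN(C(=O)OC3COC3)CC2)c1F`, gives 66% in a functional assay on isolated protein for inhibition of Glucose-dependent insulinotropic receptor (Rattus norvegicus), read by HTRF and cAMP accumulation; on this read-out lower numbers stand for smaller maximal responses and higher numbers for larger maximal responses.
Compound 2, `Cc1nc(S(C)(=O)=O)ccc1Oc1ncnc(OC2CCN(C(=O)SC(C)(C)C)CC2)c1F`, gives 76% in this assay.
Compound 3, `Cc1nc(S(C)(=O)=O)ccc1Oc1ncnc(OC2CCN(C(=S)OC(C)C)CC2)c1F`, gives 47% in this assay.

Compound 3 stands lowest of the three numbers. Its nearest neighbour is compound 1, with a number 19 percentage points lower from compound 1 to compound 3 (beyond the scatter), and furthest is compound 2, with a number 29 percentage points lower from compound 2 to compound 3 (beyond the scatter). Compound 1 and compound 2 lie within the scatter of each other, as a number 10 percentage points higher from compound 1 to compound 2 (within the scatter) shows.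

Compound 4, `Cc1nc(S(C)(=O)=O)ccc1Oc1ncnc(OC2CCN(C(=O)c3nc(C(C)(C)F)no3)CC2)c1F`, is not yet measured. It differs from compound 3 only at the amine nitrogen in the ring: a group of 11 heavy atoms (6 carbon, 2 nitrogen, 2 oxygen, 1 fluorine; one five-membered aromatic ring with 3 hetero atoms) in place of a group of 6 heavy atoms (4 carbon, 1 oxygen, 1 sulfur; no ring), on an amine nitrogen in a ring. Going by the values given here, both measured steps at this position that reach compound 3 are modest and point downward into it, so every other group tried at this place gave a larger maximal response than the one in compound 3. Among the compounds with values here, the new group in compound 4 has no measured counterpart, so its own effect is unknown. On the two steps alone, compound 4 is expected to move back upward by about a number 18 percentage points higher from compound 3 to compound 4 (beyond the scatter) in this assay. The estimate for compound 4 is therefore 65%, with a range from 45% to 85%.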

Compound 4, largest response reached (reported as efficacy), in percent of the reference or control that the assay uses: 84%
For compound 4 the middle estimate is 19 percentage points below the measured one, within the range that was stated.
By their numbers in this assay, from the lowest: compound 3; then compounds 1, 2 and 4 (each within the scatter of the next, the first and the last beyond it).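

With the group carrying a five-membered aromatic ring on the amine nitrogen in the ring, the response in this assay is on a level with that of the open-chain group in compound 2 (a number 8 percentage points higher from compound 2 to compound 4 (within the scatter)), so a ring of this kind does not cost response at this position. Going by these compounds alone, the same group clearly exceeds the oxetane-bearing group (a number 18 percentage points higher from compound 1 to compound 4 (beyond the scatter)) and gives the only large step seen here (a number 37 percentage points higher from compound 3 to compound 4 (beyond the scatter)), which widens the span of responses this one position can produce. Nothing available accounts for these differences.

The compounds shown do not separate the contribution of the aromatic ring from that of the fluorine-bearing side chain on it. A plain isopropyl group on the same ring, or an amine on the carbonyl carbon, would address how far this position depends on either feature.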